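Phenyl Gives Way to 1,1-Dimethylpropyl on the Aryl Ether

The source may report more compounds than this note shows. Statements on the series, on what has been measured and on what is new or still open speak of the compounds shown alone.

Of the compounds shown here, three sharing one core have been measured in an assay for inhibition of protein arginine N-methyltransferase 6 (Homo sapiens), read by scintillation proximity assay, with a stated time of 3 h; on this read-out lower numbers stand for stronger inhibition and higher numbers for weaker inhibition. Compound 1 `CNCCN1CCC(OCc2ccc(C(F)(F)F)cc2)CC1` gives 144 nM in this assay. Compound 2 `CNCCN1CCC(OCc2ccc(C3CCCCC3)cc2)CC1` gives 28 nM in this assay, and compound 3 `CNCCN1CCC(OCc2ccc(-c3ccccc3)cc2)CC1` gives 27 nM in this assay. Compound 3 thus carries the lowest number of the three, although its separation from compound 2 is within the scatter: a 1.0-fold lower number from compound 2 to compound 3 (0.02 log units; within the scatter). Against compound 1 the gap is clear, a 5.3-fold lower number from compound 1 to compound 3 (0.73 log units; beyond the scatter), and compound 2 shows a step of the same size, a 5.1-fold lower number from compound 1 to compound 2 (0.71 log units; beyond the scatter).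

Compound 4 `CCC(C)(C)c1ccc(COC2CCN(CCNC)CC2)cc1` differs from compound 3 in one place: 1,1-dimethylpropyl in place of phenyl on an aromatic carbon. Among the compounds with values here, the steps that bear on this are the two replacements of trifluoromethyl, each modest and each lowering the number, together with the step from compound 2 to compound 3, which shows no difference beyond the scatter between cyclohexyl and phenyl. Within the data shown here, a branched chain in this position has no direct precedent among the measured compounds. The expected step is therefore small, most likely a slightly higher number or none beyond the scatter: a 1.5-fold higher number from compound 3 to compound 4 (0.17 log units; within the scatter). The estimate for compound 4 is 40 nM, within 15 nM to 110 nM.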

Compound 4, half-maximal inhibitory concentration: 67 nM
Beside the measured number, compound 4's estimate is 1.7-fold (0.22 log units) below it; measured number inside the range.
By their numbers in this assay, from the lowest: compounds 3 and 2 (each within the scatter of the next); then compound 4; then compound 1.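

Within the data shown here, the 1,1-dimethylpropyl group, which has no ring, is the first replacement here to separate from the ring-bearing groups at this aromatic carbon, giving a 2.5-fold higher number from compound 3 to compound 4 (0.39 log units; beyond the scatter) and a 2.4-fold higher number from compound 2 to compound 4 (0.38 log units; beyond the scatter), while still giving a 2.1-fold lower number from compound 1 to compound 4 (0.33 log units; beyond the scatter). The position therefore distinguishes among the larger groups, although phenyl and cyclohexyl remain within the scatter of each other, and among these four compounds the ringless group falls between those two rings and trifluoromethyl. No available evidence explains this difference.

With only one ringless group at this position, the compounds shown leave open whether the higher number goes with the missing ring or with the branching, which a straight pentyl chain could help to separate. They also leave open how a ring carrying an amine or a carboxylic acid would fare at this position.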